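Notes on the shared core: chloro to isopropyl step

A few compounds are considered here, and "the series" means these few. Any claim that something is new, unique, unknown or untested is made for them only; others in the source may bear on it.

Three compounds of the shared core carry a result in a functional assay on LS174T cells (Homo sapiens) for inhibition, read by MTT assay, with a stated time of 72 h; on this read-out lower numbers stand for stronger inhibition and higher numbers for weaker inhibition. Compound 3 `O=C(O)/C=C/C(=O)c1ccc(Cl)cc1` gives 28700 nM and stands highest of the two numbers recorded so far. Its nearest neighbour is compound 2 `CC(C)(C)c1ccc(C(=O)/C=C/C(=O)O)cc1`, which in this assay gives 8740 nM, so that the step of a 3.3-fold higher number from compound 2 to compound 3 (0.52 log units; beyond the scatter) was modest in size. Compound 1 `O=C(O)/C=C/C(=O)c1ccc(Cl)cc1Cl` reached only > 100000 nM in this assay, which is a limit of the assay rather than a number. From that limit the step of an at least 3.4-fold lower number from compound 1 to compound 3 (0.54 log units; beyond the scatter) was at least modest.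

Compound 4 `CC(C)c1ccc(C(=O)/C=C/C(=O)O)cc1` is not yet measured. It differs from compound 3 by isopropyl in place of chloro on an aromatic carbon. The step that bears most directly on this change is a 3.3-fold higher number from compound 2 to compound 3 (0.52 log units; beyond the scatter). It exchanges the same chloro for a branched alkyl group. The step of an at least 3.4-fold lower number from compound 1 to compound 3 (0.54 log units; beyond the scatter) concerns a chloro at a different position and is less telling. A lower number is therefore expected in this assay for compound 4, in the same direction as the step to tert-butyl, though it may not reach its full extent.

Compound 4 is expected to give about 12000 nM in this assay, with a range from 5000 nM to 35000 nM. This estimate would mean a step of a 2.4-fold lower number from compound 3 to compound 4 (0.38 log units; beyond the scatter).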

Compound 4, half-maximal inhibitory concentration: 25700 nM
The estimate for compound 4 lay 2.1-fold (0.33 log units) below the measured number; low and high end bracket the measured number.
By their numbers in this assay, from the lowest: compound 2; then compounds 4 and 3 (each within the scatter of the next). At a limit, above all of these: compound 1.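

In this assay, the step of a 1.1-fold lower number from compound 3 to compound 4 (0.05 log units; within the scatter) leaves isopropyl and chloro without a readable difference at this position, on an aromatic carbon para to a group of 7 heavy atoms. The earlier step to tert-butyl therefore cannot be read as a general result of placing a branched alkyl group here, at least for the compounds shown. The step of a 2.9-fold higher number from compound 2 to compound 4 (0.47 log units; beyond the scatter) places the separation between isopropyl and tert-butyl, a change of one methyl on the saturated chain carbon bound to the aromatic carbon, and no measurement shown here accounts for that step or for the lack of a readable difference between chloro and isopropyl.

Still open, as far as these compounds go, is whether the lower number of compound 2 belongs to tert-butyl alone or extends to other groups at this position, such as trifluoromethyl, methoxy, an amine or a longer chain. Also open, from the compounds shown here alone, is whether the steps seen at this position would hold if an ester or an amide took the place of the carboxylic acid of the shared core.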